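The source may report more compounds than this note shows. Statements on the series, on what has been measured and on what is new or still open speak of the compounds shown alone.

Cytotoxicity in this series is read in an ADME assay on TERT-RPE1 cells (Homo sapiens) for cytotoxicity, read by MTT assay, with a stated time of 72 h; on this read-out lower numbers stand for stronger inhibition and higher numbers for weaker inhibition. Compound 1 `C=CC/N=C1\S/C(=C\c2ccc(OC)cc2)C(=O)N1C` gives > 100000 nM, which is a limit of the assay. Compound 2 `COc1ccc(/C=C2/CN(C)/C(=N/c3ccc(C(C)(C)C)cc3)S2)cc1` gives 23500 nM. Compound 3 `COc1ccc(/C=C2\S/C(=N\c3ccc(Cl)cc3)N(C)C2=O)cc1` likewise sits at a limit, > 100000 nM. The step that the two limits leave unreadable from compound 1 to compound 3 therefore cannot be sized, since both ends rest on (the limit of > 100000 nM in this assay, at which 2 of the 3 values shown sit). Compound 4 `COc1ccc(/C=C2\S/C(=N\c3ccc(C)c(Cl)c3)N(C)C2=O)cc1` differs from compound 3 by 3-chloro-4-methylphenyl in place of 4-chlorophenyl on a double-bonded nitrogen. Within the data shown here, no measured step bears directly on this change; the only single-point step recorded is unreadable. Compound 3 stands at the limit, and the 3-chloro-4-methylphenyl is expected to leave the read-out there, so the expected step of a number no higher from compound 3 to compound 4 (the limit leaves the size open) is none beyond the scatter. Compound 4 is estimated at 100000 nM, between 40000 nM and 300000 nM, and is most likely to be reported again only as a limit.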

Compound 4, half-maximal inhibitory concentration: 23000 nM
Compound 4: the middle estimate sits 4.3-fold (0.64 log units) above what was measured; the whole stated range lies above it.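

In this assay, 3-chloro-4-methylphenyl on a double-bonded nitrogen gives an at least 4.3-fold lower number from compound 3 to compound 4 (0.63 log units; beyond the scatter) and an at least 4.3-fold lower number from compound 1 to compound 4 (0.63 log units; beyond the scatter), so a change at this position can bring the read-out off the limit. Among these compounds, the earlier step at this position could not be read, so this is the first readable effect here. Both sizes are lower bounds only, because each starting compound rests on a limit: the limit of > 100000 nM in this assay, at which 2 of the 4 values shown sit.

On these data alone, how the step divides between the added methyl and the changed chlorine placement stays open. Also open, as far as these compounds go, is how an amine or a carboxylic acid on the phenyl ring would read here.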